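The source may hold more compounds than are shown below. What is called first, only, known or untested is meant among the compounds shown, and "the series" means these compounds.

Working notes on a physicochemical assay for solubility, at pH 7.4; on this read-out higher numbers stand for higher solubility and lower numbers for lower solubility. Compound 1 (`CCCCNc1nc(NCCCC)c2ccccc2n1`) gives <= 10000 nM, which is a limit and not a number. Compound 2 (`CCCCNc1nc(NCc2ccccc2)c2ccccc2n1`) gives <= 10000 nM, also a limit. Both measured compounds therefore sit at the limit of <= 10000 nM in this assay, at which 2 of the 2 values shown sit. Compound 3 (`CCCCNc1nc(NCc2ccccc2)nc2ccccc12`) is not yet measured. It differs from compound 1 by phenyl in place of propyl on a saturated chain carbon bound to a nitrogen on an aromatic ring. Among the compounds with values here, the one measured step of this kind, a step that the two limits leave unreadable from compound 1 to compound 2, offers no size or direction to carry over, so no change beyond the scatter is expected in this assay. The expected step is a step that the limit leaves unreadable from compound 1 to compound 3. For compound 3 the estimated value is 6000 nM, with an expected range of 1500 nM to 10000 nM.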

Compound 3, solubility: <= 10000 nM
Compound 3 ended at the assay's limit; the forecaster's own chance of this, stated with the estimate: 85%; the middle value is on the limit's open side.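

Within the data shown here, compound 3, like compound 1, gives only a limit, so no step between the two can be read in this assay: the limit of <= 10000 nM in this assay, at which 3 of the 3 values shown sit. The compounds shown leave open whether the butyl to benzyl change moves this assay at all, in size or direction.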